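Swapping the aryl amide on a fixed chain length

The source may report more compounds than this note shows. Statements on the series, on what has been measured and on what is new or still open speak of the compounds shown alone.

Of the compounds shown here, three have been measured in an assay on isolated protein (Mus musculus) for inhibition of IL15-IL15 receptor (Homo sapiens), read by resazurin assay, with stated times of 30 min and 2.5 days; on this read-out lower numbers stand for stronger inhibition and higher numbers for weaker inhibition. Compound 1 `Cn1c(Cc2nn(C)c(=O)c3ccccc23)nnc1SCCCCCCCCCCCCCCCC(=O)Nc1ccc(Cl)cc1Cl` gives 7300 nM, compound 2 `Cn1c(Cc2nn(C)c(=O)c3ccccc23)nnc1SCCCCCC(=O)Nc1ccc(Cl)cc1Cl` gives 4100 nM, and compound 3 `Cn1c(Cc2nn(C)c(=O)c3ccccc23)nnc1SCCCCCCCC(=O)Nc1ccc(I)cc1` gives 1300 nM, the lowest of the three numbers and beyond the scatter from both others. Compound 4 `Cn1c(Cc2nn(C)c(=O)c3ccccc23)nnc1SCCCCCCCC(=O)Nc1ccc(Cl)cc1Cl` carries 2,4-dichlorophenyl in place of 4-iodophenyl on an amide-type nitrogen, so it keeps the chain of compound 3 while taking the aryl group that compounds 1 and 2 share.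

Going by the values given here, only one measured step bears on this change directly: a 3.2-fold lower number from compound 2 to compound 3 (0.50 log units; beyond the scatter), but that step combines a change of the aryl group with a change of chain length. The share of the aryl group alone cannot be separated from it. Compounds 1 and 2, which both carry the 2,4-dichlorophenyl group on chains of different length, give numbers higher than compound 3, and compound 4 sits between them in chain length. The author therefore expects compound 4 to move back toward those two numbers, with a step of a 2.7-fold higher number from compound 3 to compound 4 (0.43 log units; beyond the scatter), a moderate rise in this assay. The estimate for compound 4 is 3500 nM, with a range from 1500 nM to 9000 nM.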

Compound 4, half-maximal inhibitory concentration: 1900 nM
Beside the measured number, compound 4's estimate is 1.8-fold (0.27 log units) above it; the range from low to high includes it.
By their numbers in this assay, from the lowest: compounds 3 and 4 (each within the scatter of the next); then compounds 2 and 1 (each within the scatter of the next).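

In this assay, exchanging 4-iodophenyl for 2,4-dichlorophenyl on the amide-type nitrogen with the chain held fixed gives a 1.5-fold higher number from compound 3 to compound 4 (0.16 log units; within the scatter), so the two aryl groups cannot be told apart on this chain. The earlier 3.2-fold lower number from compound 2 to compound 3 (0.50 log units; beyond the scatter) therefore need not be credited to the aryl group, and with 2,4-dichlorophenyl kept in place, compound 2 gives 4100 nM and compound 4 gives 1900 nM, which points to the chain as the part of that earlier step that counts here. Nothing at hand explains why the two aryl groups read alike in this assay.

It remains open whether the two aryl groups would also read alike on the shorter chain of compound 2 or the longer chain of compound 1, and how chains of intermediate length would fall among these values. Also open, on these data alone, is whether an unsubstituted phenyl ring, a pyridine ring, or a phenyl ring carrying an amine or a carboxylic acid would hold the same level on the amide-type nitrogen, since both aryl groups compared here are halogen-bearing phenyl rings.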